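Fluoro to hydrogen on compound 2, at the assay limit

The source may report more compounds than this note shows. Statements on the series, on what has been measured and on what is new or still open speak of the compounds shown alone.

In a functional assay on HL-60 cells (Homo sapiens) for antiproliferative activity, read by MTT assay, with a stated time of 72 h (on this read-out higher numbers stand for weaker inhibition and lower numbers for stronger inhibition), compound 1 `COc1ccc(-c2ncnn2-c2cc(OC)c(OC)c(OC)c2)cc1` gives 120 nM. Compound 2 `COc1cc(-c2ncnn2-c2ccc(F)cc2)cc(OC)c1OC` is known only as a limit, > 10000 nM. Compound 3 `COc1cc(-n2ncnc2-c2ccc(Cl)c(Cl)c2)cc(OC)c1OC` is likewise known only as a limit, > 10000 nM. The measured set thus comes down to one number and (the limit of > 10000 nM in this assay, at which 2 of the 3 values shown sit), so compound 2 has no exact place on the scale.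

Compound 4 `COc1cc(-c2ncnn2-c2ccccc2)cc(OC)c1OC` differs from compound 2 in one place: hydrogen in place of fluoro on an aromatic carbon. Hydrogen stands in place of fluoro on an aromatic carbon, para to a large group, which turns 4-fluorophenyl into phenyl.

Among the measured compounds shown here, the only measured step, an at least 83-fold higher number from compound 1 to compound 3 (1.92 log units; beyond the scatter), is large, so this assay can respond strongly to a single exchange. For the measured compounds named here, that step, however, puts 3,4-dichlorophenyl in place of 4-methoxyphenyl, and no measured step replaces fluoro with hydrogen. It therefore gives no direct measure for the present change. No step beyond the scatter is expected in this assay, in either direction, and compound 4 may also be reported only as a limit. The expected change is a step that the limit leaves unreadable from compound 2 to compound 4. Compound 4 is estimated at 12000 nM, with an expected range from 4000 nM to 30000 nM.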

Compound 4, half-maximal inhibitory concentration: > 10000 nM
Compound 4 ended at the assay's limit; the forecaster's own chance of this, stated with the estimate: 75%; the middle value lies beyond the limit too.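

No step can be read between compound 2 and compound 4 for the exchange of fluoro for hydrogen, as neither has an exact value in this assay: the limit of > 10000 nM in this assay, at which 3 of the 4 values shown sit.

The compounds shown leave open whether 4-fluorophenyl and phenyl differ at all in this assay, and how far beyond the limit either compound lies.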